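Swapping Methoxy for Chloro on a Shared Core

This account rests on a few compounds, and the source may have more. Where it says the series, first, only, none or still open, it means among the compounds named here.

Compound 1 `COc1cc(/C=C/C(=O)c2cccc(-n3cc(-c4ccccc4)[nH]c3=O)c2)ccc1O` gives 3310 nM in a functional assay on SN12C cells (Homo sapiens) for inhibition; a lower number here means a stronger inhibitor of growth, a higher number a weaker inhibitor of growth.
Compound 2 `O=C(/C=C/c1cccc(O)c1)c1cccc(-n2cc(-c3ccc(Cl)cc3)[nH]c2=O)c1` gives 1950 nM in this assay.
Compound 3 `COc1ccc(-c2cn(-c3cccc(C(=O)/C=C/c4ccc(O)c(OC)c4)c3)c(=O)[nH]2)cc1` gives 4110 nM in this assay.

Compound 3 stands at the highest of the three numbers. Among the measured compounds shown here, its nearest neighbour is compound 1, and the one single-point step among the measured compounds, a 1.2-fold higher number from compound 1 to compound 3 (0.09 log units; within the scatter), lies within the scatter. For the measured compounds named here, compound 2 stands furthest from compound 3, with a lower number beyond the scatter; compound 2 differs from compound 3 in more than one place, so its value alone shows only that a compound carrying the 4-chlorophenyl group can reach a lower number in this assay.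

Compound 4 `COc1cc(/C=C/C(=O)c2cccc(-n3cc(-c4ccc(Cl)cc4)[nH]c3=O)c2)ccc1O` has not yet been measured. It differs from compound 3 by chloro in place of methoxy on an aromatic carbon. Going by the values given here, the only measured step that touches this position, from compound 1 to compound 3, was within the scatter, and no measured step isolates the chloro group. On that thin basis a small downward step is expected for compound 4, of about a 1.6-fold lower number from compound 3 to compound 4 (0.20 log units; within the scatter). Compound 4 is therefore estimated at 2600 nM in this assay, with a likely range from 1200 nM to 5800 nM.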

Compound 4, concentration for 50% growth inhibition: 2870 nM
Compound 4: the middle estimate sits 1.1-fold (0.04 log units) below what was measured, and the stated range covers the measured number.
By their numbers in this assay, from the lowest: compounds 2, 4, 1 and 3 (each within the scatter of the next, the first and the last beyond it).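

Among the compounds shown here, the step of a 1.4-fold lower number from compound 3 to compound 4 (0.16 log units; within the scatter) is the first to isolate chloro against methoxy on this aromatic carbon, and a 1.2-fold lower number from compound 1 to compound 4 (0.06 log units; within the scatter) adds chloro against hydrogen, so that in this assay hydrogen, methoxy and chloro have now all been compared at this place and no step among them goes beyond the scatter. At the other end of the molecule, a 1.5-fold higher number from compound 2 to compound 4 (0.17 log units; within the scatter) shows that 4-hydroxy-3-methoxyphenyl and 3-hydroxyphenyl can also be exchanged with the 4-chlorophenyl group in place without leaving the scatter, so neither single change shown here moves the number by more than that. Nothing measured alongside these growth numbers bears on why the groups at this position read alike.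

On these data alone, whether this flat picture holds for a very different group on the same carbon, such as an amine, a carboxylic acid or a longer chain in place of the methoxy, remains open. For the compounds shown here, it is also open whether the exchange of the two hydroxyphenyl groups reads the same with hydrogen or methoxy on that carbon, since the exchange is seen only with chloro there.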